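The compounds below may be only part of what the source reports. "The series", "measured", "known", "first", "only" and "open" are said of these compounds alone.

Compounds measured so far:
compound 1 `CC(=O)N(C)c1ccc(Nc2nccc(-c3cccnc3)n2)cc1` gives 900 nM;
compound 2 `Cc1cccc(Nc2nccc(-c3ccccn3)n2)c1` gives 700 nM;
compound 3 `CC(=O)N(C)c1ccc(Nc2nccc(-c3ccccn3)n2)cc1` gives 1800 nM.

These three numbers come from a functional assay for inhibition, with Homo sapiens as the target; a higher number here means a weaker inhibitor, a lower number a stronger inhibitor. Among them compound 1 holds the second highest number; compound 2 is nearest to it and compound 3 furthest, yet both gaps are within the scatter, so none of the three can be called the stronger or weaker inhibitor on this evidence.

Going by the values given here, the only single-point step that has been measured is a 2.0-fold higher number from compound 1 to compound 3 (0.30 log units; within the scatter), which alters the aromatic group attached to the shared core and says nothing about the other end of the molecule.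

Compound 4 `CC1CCN(c2ccc(Nc3nccc(-c4cccnc4)n3)cc2)CC1` differs from compound 1 at that other end: 4-methylpiperidin-1-yl in place of acetyl(methyl)amino on an aromatic carbon.

Among the compounds with values here, no measured step touches this position, so there is nothing to build a directional expectation on. The step from compound 1 to compound 4 is therefore expected to stay within the scatter, and the expected outcome is no change at the digits printed from compound 1 to compound 4 (within the scatter). In this assay compound 4 is estimated at 900 nM, with a range from 300 nM to 2700 nM.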

Compound 4, half-maximal inhibitory concentration: 500 nM
The estimate for compound 4 lay 1.8-fold (0.26 log units) above the measured number; the range from low to high includes it.
By their numbers in this assay, from the lowest: compounds 4, 2, 1 and 3 (each within the scatter of the next, the first and the last beyond it).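

In this assay the swap at this position gives a 1.8-fold lower number from compound 1 to compound 4 (0.26 log units; within the scatter) and so shows no change that can be told apart from the scatter. The open acetyl(methyl)amino group, which has no ring, gives way to 4-methylpiperidin-1-yl, a six-membered non-aromatic ring with more heavy atoms and no oxygen, so in this single case the position accepts a clearly different group with no readable gain or loss as an inhibitor. No measured information here bears on why the swap has so little effect on the number.

As far as these compounds go, it remains open whether a morpholin-4-yl group or a carboxylic acid at this position would move the number beyond the scatter. Also open, from the compounds shown here alone, is whether 4-methylpiperidin-1-yl would give the same result with pyridin-2-yl in place of pyridin-3-yl on the shared core.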